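Swapping the amide aryl group while toxicity stays low

The source may report more compounds than this note shows. Statements on the series, on what has been measured and on what is new or still open speak of the compounds shown alone.

Three compounds built on one shared core were tested in a toxicity assay on THP-1 cells (Homo sapiens) for inhibition; on this read-out higher numbers stand for lower toxicity in this test and lower numbers for higher toxicity in this test. Compound 1 `Cn1c(-c2ccc(C#N)cc2)cnc1NC(=O)c1ccc(F)cc1` carries a nitrile-bearing aryl ring on the core and a 4-fluorophenyl on the carbonyl carbon. In this assay compound 1 gives > 50000 nM, which is a limit of the assay and not a number. Compound 2 `COc1ccc(-c2cnc(NC(=O)c3ccccn3)n2C)cc1` combines a different aryl ring on the core with a pyridin-2-yl on the carbonyl carbon. In this assay compound 2 gives > 100000 nM, again only a limit. Compound 3 `Cn1c(-c2ccccc2)cnc1NC(=O)c1cccc(Cl)c1` gives > 50000 nM in this assay, also a limit. So compound 2 stands at the limit of > 100000 nM in this assay, at which 1 of the 3 values shown sits, while the other two sit at the limit of > 50000 nM in this assay, at which 2 of the 3 values shown sit; none of the three reaches a measurable toxic concentration. Compound 4 `COc1ccc(-c2cnc(NC(=O)c3ccc(F)cc3)n2C)cc1` is compound 2 with 4-fluorophenyl in place of pyridin-2-yl on a carbonyl carbon. Within the data shown here, no measured pair of compounds isolates this change, so the step of an at least 1.2-fold lower number from compound 2 to compound 4 (0.09 log units; that floor lies within the scatter) is expected to stay within the usual scatter. Compound 4 is therefore estimated at 80000 nM, within 30000 nM to 200000 nM, and most likely reported again only as a limit.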

Compound 4, half-maximal cytotoxic concentration: >= 50000 nM
Compound 4: no number, only a limit; the forecaster's own chance of this, stated with the estimate: 85%; the middle value is on the limit's open side.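

Compound 4 also gives only a limit, so neither the step from compound 2 to compound 4 nor the step from compound 1 to compound 4 can be read. The compounds shown leave open at what concentration any of them becomes toxic in this assay.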